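Removal of the methyl group from compound 3

The compounds below may be only part of what the source reports. "The series", "measured", "known", "first", "only" and "open" are said of these compounds alone.

Going by the values given here, compound 3 `Cc1cccc(/C(N)=N/NC(=S)N2CCCC2)n1` gives the highest of the three numbers measured so far in a functional assay on A-375 cells (Homo sapiens) for cytotoxicity, read by MTT assay, with a stated time of 72 h (on this read-out higher numbers stand for weaker inhibition and lower numbers for stronger inhibition), at 2900 nM. The nearest value belongs to compound 1 `N/C(=N\NC(=S)N1CCCC1)c1ccc(F)cn1`, which in this assay gives 860 nM; the furthest belongs to compound 2 `N/C(=N\NC(=S)N1CCCCC1)c1ccccn1`, which in this assay gives 680 nM. Both of those gaps lie beyond the usual scatter, and neither pair is a single-point change from compound 3, so only the values themselves can be compared.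

Compound 4 `N/C(=N\NC(=S)N1CCCC1)c1ccccn1` differs from compound 3 in one place: hydrogen in place of methyl on an aromatic carbon. Among the compounds with values here, no measured pair shows this change on its own. The expectation is that the number falls, since compound 1 gives 860 nM and compound 2 gives 680 nM on the same core without the methyl, which puts the step from compound 3 to compound 4 in this assay at about a 3.6-fold lower number from compound 3 to compound 4 (0.56 log units; beyond the scatter). The estimate for compound 4 in this assay is therefore 800 nM, within a range of 400 nM to 1800 nM.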

Compound 4, half-maximal inhibitory concentration: 600 nM
Beside the measured number, compound 4's estimate is 1.3-fold (0.12 log units) above it; low and high end bracket the measured number.
By their numbers in this assay, from the lowest: compounds 4, 2 and 1 (each within the scatter of the next); then compound 3.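

In this assay the methyl on the aromatic carbon next to the ring nitrogen now has a single-place reading: hydrogen in its place gives a 4.8-fold lower number from compound 3 to compound 4 (0.68 log units; beyond the scatter) and this lies beyond the scatter. The other two changes stay within the scatter, with pyrrolidin-1-yl in place of piperidin-1-yl giving a 1.1-fold lower number from compound 2 to compound 4 (0.05 log units; within the scatter) and hydrogen in place of fluoro giving a 1.4-fold lower number from compound 1 to compound 4 (0.16 log units; within the scatter) in this set. Of these three steps only the methyl change moves the number beyond the scatter, so the high value of compound 3, 2900 nM, goes with that one group.

As far as these compounds go, whether chloro, methoxy or an amine on the same carbon would track with methyl or with hydrogen remains open, as does the same step with piperidin-1-yl on the thiocarbonyl carbon. Nothing at hand gives a reason for the size of this step.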